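Side-chain variation at the saturated ring carbon: amide replaces alkene

The source may hold more compounds than are shown below. What is called first, only, known or untested is meant among the compounds shown, and "the series" means these compounds.

Three compounds of the series have been run in a functional assay on OVCAR-8 cells (Homo sapiens) for antiproliferative activity; on this read-out higher numbers stand for weaker inhibition and lower numbers for stronger inhibition. Compound 1 `CC(=O)OCC[C@@H]1C[C@@H](c2ccc(F)c(F)c2)[C@H](NC(=O)c2cc(-c3c(Cl)cnn3C)c(Cl)o2)CN1` gives 4960 nM. Compound 2 `C=CC[C@@H]1C[C@@H](c2ccc(Cl)c(Cl)c2)[C@H](NC(=O)c2cc(-c3c(Cl)cnn3C)c(Cl)o2)CN1` gives 990 nM. Compound 3 `Cn1ncc(Cl)c1-c1cc(C(=O)N[C@@H]2CN[C@H](CC(O)CO)C[C@H]2c2ccc(F)c(F)c2)oc1Cl` gives 690 nM. On these numbers compound 2 stands second highest of the three: compound 3 lies within the scatter of it, while compound 1 sits beyond the scatter above it.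

Among the compounds with values here, the one single-point step among the measured compounds runs a 7.2-fold lower number from compound 1 to compound 3 (0.86 log units; beyond the scatter) and concerns the same chain position that is varied next.

Compound 4 `CNC(=O)C[C@@H]1C[C@@H](c2ccc(Cl)c(Cl)c2)[C@H](NC(=O)c2cc(-c3c(Cl)cnn3C)c(Cl)o2)CN1` is not yet measured. It differs from compound 2 as follows: methylcarbamoyl in place of vinyl on a saturated chain carbon bound to a saturated ring carbon. Like the step from compound 1 to compound 3, this change brings a hydrogen-bond donor and acceptor into the chain at the saturated chain carbon bound to a saturated ring carbon, though the groups themselves differ, so the earlier step is only a loose guide. A modest lowering of the number is therefore expected, though a result within the scatter would not surprise.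

Compound 4 is estimated at 600 nM, with a range from 200 nM to 2000 nM, an expected step of a 1.7-fold lower number from compound 2 to compound 4 (0.22 log units; within the scatter).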

Compound 4, half-maximal inhibitory concentration: 1130 nM
The estimate for compound 4 lay 1.9-fold (0.27 log units) below the measured number; low and high end bracket the measured number.
By their numbers in this assay, from the lowest: compounds 3, 2 and 4 (each within the scatter of the next); then compound 1.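

In this assay the change from vinyl to methylcarbamoyl on a saturated chain carbon bound to a saturated ring carbon gives a 1.1-fold higher number from compound 2 to compound 4 (0.06 log units; within the scatter) and so stays within the scatter: with the rest of compound 2 held fixed, this position takes the larger methylcarbamoyl, with its hydrogen-bond donor and acceptor, without a readable shift in the number. The earlier step at this chain position, a 7.2-fold lower number from compound 1 to compound 3 (0.86 log units; beyond the scatter), lay beyond the scatter, so the entry of a hydrogen-bond donor and acceptor here does not by itself bring a step of that size, at least for the methylcarbamoyl change on compound 2. Nothing available bears on why the two steps differ in size.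

Compounds 3 and 4 differ in more than one place, which leaves open how methylcarbamoyl and 1,2-dihydroxyethyl compare on a single background, and whether methylcarbamoyl would give a similar result on the core of compound 1. Also open, as far as these compounds go, is how this position responds to a primary amine, a carboxylic acid or a longer chain carrying the amide.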